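A Chloro Step Repeated on a Second Core

The source may hold more compounds than are shown below. What is called first, only, known or untested is meant among the compounds shown, and "the series" means these compounds.

Measured so far:
Compound 1 `O=c1[nH]nc2n(c1=O)CCN2c1ccccc1` gives 0% in a functional assay on T47D cells (Homo sapiens) for cytotoxicity, with a stated time of 72 h, tested at 10 ug/mL; a lower number here means a weaker effect, a higher number a stronger effect of the compound at the concentration tested.
Compound 2 `N=c1c(=O)[nH]nc2n1CCN2c1ccccc1` gives 0% in this assay.
Compound 3 `O=c1[nH]nc2n(c1=O)CCN2c1ccc(Cl)cc1` gives 5% in this assay.

Compound 3 differs from compound 1 by chloro in place of hydrogen on an aromatic carbon; this change moved the read-out by a number 5 percentage points higher from compound 1 to compound 3 (within the scatter). Compound 2 sits level with compound 1 at the digits reported, and the difference between the two cores is not broken down here. The unmeasured compound 4 `N=c1c(=O)[nH]nc2n1CCN2c1ccc(Cl)cc1` differs from compound 2 by chloro in place of hydrogen on an aromatic carbon, the same change made from compound 1 to compound 3, at a place described in the same words. Because a number 5 percentage points higher from compound 1 to compound 3 (within the scatter) stayed within the scatter, the step from compound 2 to compound 4 is expected to be a number 4 percentage points higher from compound 2 to compound 4 (within the scatter). Compound 4 is therefore expected to give about 4% in this assay, with a range from 0% to 15%.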

Compound 4, a percentage reported as inhibition, at one concentration (the size of the read-out at that concentration, not a potency): 16%
For compound 4 the middle estimate is 12 percentage points below the measured one; the whole stated range lies below it.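

In this assay, putting chloro in place of hydrogen on an aromatic carbon gives a number 16 percentage points higher from compound 2 to compound 4 (beyond the scatter). This step looks larger than the one made by the same change on the other core, but the gap between the two steps is no greater than repeated measurements could produce: the same change on two cores in this assay, a number 5 percentage points higher (within the scatter) from compound 1 to compound 3 and a number 16 percentage points higher (beyond the scatter) from compound 2 to compound 4, 11 percentage points apart, within the scatter of two such steps The two cores therefore cannot be said to respond differently to chloro, although a single pair on each core does not show that they respond alike.

Still open, on these data alone, is how other groups at the same place, such as a methoxy group, an amine or a carboxylic acid, would behave on each core. As far as these compounds go, whether a longer chain there would give a step of similar size on both cores is also open.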